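This account rests on a few compounds, and the source may have more. Where it says the series, first, only, none or still open, it means among the compounds named here.

Compound 1 `C/C=C(\C)C1=C(CO)[C@H](O)[C@H]2O[C@H]2C1=O` carries a 1-methylprop-1-en-1-yl group on its core. In a functional assay on Jurkat cells (Homo sapiens) for cytotoxicity (a lower number here means a stronger inhibitor, a higher number a weaker inhibitor), compound 1 gives only a limit of the assay, > 80000 nM, and no number. Its place among the measured compounds is therefore at the weak end, since (the limit of > 80000 nM in this assay, at which 1 of the 3 values shown sits). Compound 2 `CCCC/C=C/C1=C(CO)C(=O)[C@H]2O[C@H]2C1=O` gives 10000 nM in this assay. Compound 3 `C/C=C/C1=C(CO)[C@@H](O)[C@@H]2O[C@@H]2C1=O` gives 60000 nM in this assay, and the gap between compound 2 and compound 3 is wider than the scatter.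

Compound 4 `O=C1C=C(CO)[C@H](O)[C@H]2O[C@@H]12` is not yet measured. The change from compound 1 to compound 4 is hydrogen in place of 1-methylprop-1-en-1-yl on a double-bonded ring carbon. Both alkenyl-bearing compounds, compound 2 and compound 3, show numbers, while compound 1 stops at a limit, so removing the side chain entirely gives no ground to expect a gain. The step from compound 1 to compound 4 is expected to be none beyond the scatter, or a loss, as a step that the limit leaves unreadable from compound 1 to compound 4. Compound 4 is thus estimated at 120000 nM, within 40000 nM to 400000 nM, and most likely reported as a limit.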

Compound 4, half-maximal inhibitory concentration: > 80000 nM
Compound 4 gave a limit, no number; the forecaster's own chance of this, stated with the estimate: 75%; the middle value does not contradict the limit.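

Compound 1 and compound 4 both stop at a limit of the assay and give no number, so no step between them can be read: the limit of > 80000 nM in this assay, at which 2 of the 4 values shown sit.

In this assay the compounds shown leave open whether the 1-methylprop-1-en-1-yl group of compound 1 contributes anything to activity.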